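Lengthening the Carbamate Chain on a Selenocyanate Core

A few compounds are considered here, and "the series" means these few. Any claim that something is new, unique, unknown or untested is made for them only; others in the source may bear on it.

Measured compounds:
- compound 1, `CCCOC(=O)Nc1ccc([Se]C#N)cc1`: 46300 nM
- compound 2, `CCCCOC(=O)Nc1ccc([Se][Se]c2ccc(NC(=O)OCCCC)cc2)cc1`: 49600 nM
- compound 3, `O=C(Nc1ccc([Se][Se]c2ccc(NC(=O)Oc3ccccc3)cc2)cc1)Oc1ccccc1`: 8600 nM

In an ADME assay on BEAS-2B cells (Homo sapiens) for cytotoxicity, read by MTT assay, with a stated time of 72 h (on this read-out lower numbers stand for stronger inhibition of growth and higher numbers for weaker inhibition of growth), compound 1 gives 46300 nM, the second highest of the three numbers. Compound 2, which gives 49600 nM, sits within the scatter of compound 1, so the two cannot be told apart. Compound 3, which gives 8600 nM, lies beyond the scatter on the low side and so shows the stronger growth inhibition of the three.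

The unmeasured compound 4, `CCCCOC(=O)Nc1ccc([Se]C#N)cc1`, differs from compound 1 by one change: methyl in place of hydrogen on a saturated chain carbon, three bonds along the chain from an oxygen next to a carbonyl group. The same difference, cut one bond further out, reads propyl to butyl. Going by the values given here, no pair of measured compounds shares this single change; compound 2 carries the butyl carbamate but on a different core, so it gives no direct guide.

Among the compounds with values here, with nothing among the measured compounds pointing either way, compound 4 is expected to stay close to compound 1 in this assay, and the step from compound 1 to compound 4 is estimated at a 1.2-fold lower number from compound 1 to compound 4 (0.06 log units; within the scatter), a change no larger than the scatter. Compound 4 is therefore expected to give about 40000 nM, within a range of 18000 nM to 90000 nM.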

Compound 4, concentration for total growth inhibition: 12200 nM
Compound 4: middle estimate off by 3.3-fold (0.52 log units), on the high side; the measured number lies below the stated range.
By their numbers in this assay, from the lowest: compounds 3 and 4 (each within the scatter of the next); then compounds 1 and 2 (each within the scatter of the next).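

In this assay, methyl in place of hydrogen on a saturated chain carbon, three bonds along the chain from an oxygen next to a carbonyl group, gives a 3.8-fold lower number from compound 1 to compound 4 (0.58 log units; beyond the scatter) and so lies beyond the usual scatter. Going by these compounds alone, this is the first single-change step at this position, and it shows that the propyl to butyl change on the shared core is not silent here, even though the entering group is only one carbon with no ring and no charge. Nothing measured here accounts for the size or direction of this step.

One step cannot show whether the number keeps falling with a pentyl chain, or how a longer chain ending in an amine would behave. Whether propyl to butyl acts the same way on the core of compound 2 also remains open, as only the butyl member of that core is shown.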